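The source may hold more compounds than are shown below. What is called first, only, known or untested is meant among the compounds shown, and "the series" means these compounds.

Measured so far:
compound 1 `COc1ccc(-c2nc(COc3cccc(Cl)c3)nc3ccsc23)cn1` in an ADME assay on cells (Homo sapiens) for cytotoxicity, read by resazurin assay, with a stated time of 5 days (on this read-out higher numbers stand for lower toxicity in this test and lower numbers for higher toxicity in this test), gives > 50000 nM, a limit of the test rather than a number.
compound 2 `O=S(=O)(Cc1nc(-c2ccc(F)nc2)c2sccc2n1)c1cccc(Cl)c1` in this assay gives 40000 nM.
compound 3 `COc1ccc(-c2nc(CCS(=O)(=O)c3cccc(Cl)c3)nc3ccsc23)cn1` in this assay gives > 50000 nM, again a limit of the test.

The three compounds share one core and differ in the side arm attached to it. Compound 1 stands at the limit of > 50000 nM in this assay, at which 2 of the 3 values shown sit, so for compound 1 only a limit is known and no exact number exists. Among the compounds with values here, compound 2 is the one compound with a numerical value, and that number sits close to where the limits begin. Within the data shown here, no pair of measured compounds differs in a single place, so no measured step can be quoted here.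

Compound 4 `COc1ccc(-c2nc(CSc3ccc(F)cc3F)nc3ccsc23)cn1` differs from compound 1 by (2,4-difluorophenyl)sulfanyl in place of 3-chlorophenoxy on a saturated chain carbon bound to an aromatic carbon. Among the measured compounds shown here, with no measured step to lean on, the expectation for compound 4 rests on where compound 1 stands. In this assay compound 4 is expected to come out near 50000 nM, within a range from 20000 nM to 100000 nM, and most probably as a limit of the test once more. The step that this estimate means, a number no higher from compound 1 to compound 4 (the limit leaves the size open), is expected to be none beyond the usual scatter in this assay.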

Compound 4, half-maximal cytotoxic concentration: > 50000 nM
Compound 4 was reported as a limit; the forecaster's own chance of this, stated with the estimate: 65%; the middle value sits exactly at the limit.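

No step can be read between compound 1 and compound 4 because both are reported only as a limit of the test in this assay: the limit of > 50000 nM in this assay, at which 3 of the 4 values shown sit.

Going by these compounds, whether (2,4-difluorophenyl)sulfanyl in place of 3-chlorophenoxy changes the read-out at all stays open, as does how far apart the true values of compound 1 and compound 4 lie.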